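A few compounds are considered here, and "the series" means these few. Any claim that something is new, unique, unknown or untested is made for them only; others in the source may bear on it.

For the measured compounds named here, compound 1 `Cc1nc(-c2ccccc2)c(C(=O)N2CCN(c3cccc(C)c3C)CC2)o1` is the only compound with a numbered result in a functional assay on HL-60 cells (Homo sapiens) for inhibition, read by MTT assay, with a stated time of 72 h (a lower number here means a stronger inhibitor, a higher number a weaker inhibitor), where compound 1 gives 35 nM. Compound 2 `CC(C)(C)c1nc(-c2ccccc2F)c(C(=O)N2CCN(c3cccc(Cl)c3)CC2)o1` returns only a limit in this assay, namely > 1000 nM, the point the limit of > 1000 nM in this assay, at which 1 of the 2 values shown sits, at which one of the two values sits. Compound 3 `Cc1nc(-c2ccccc2)c(C(=O)N2CCN(c3cccc(Cl)c3)CC2)o1` is yet to be tested in this assay, and it differs from compound 1 in one place: 3-chlorophenyl in place of 2,3-dimethylphenyl on an amine nitrogen in a ring. Going by the values given here, no measured step of this kind is available, so the size of the change is uncertain. A moderate loss of potency beyond the usual scatter is expected, a 2.9-fold higher number from compound 1 to compound 3 (0.46 log units; beyond the scatter). Compound 3 is accordingly expected to give 100 nM, between 25 nM and 500 nM.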

Compound 3, half-maximal inhibitory concentration: 39.2 nM
Compound 3: middle estimate off by 2.6-fold (0.41 log units), on the high side, and the stated range covers the measured number.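

At the amine nitrogen in a ring, 3-chlorophenyl in place of 2,3-dimethylphenyl gives a 1.1-fold higher number from compound 1 to compound 3 (0.05 log units; within the scatter) in this assay. For the compounds shown here, this is the first measured step at this place, and it shows that the two substituted phenyl groups cannot be told apart here, so this change leaves the reading intact. Nothing shown accounts for this result.

The compounds shown leave open how this place responds to a phenyl bearing a methoxy group or a nitrile, or to a saturated group such as cyclohexyl. They also leave open whether the same holds when other parts of the shared core change.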